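The source may hold more compounds than are shown below. What is called first, only, known or untested is meant among the compounds shown, and "the series" means these compounds.

Compound 1, `CC(=O)N1CCC(Sc2c[nH]c3ccc(Br)cc23)CC1`, in a functional assay on the whole organism with Mus musculus as the target, in the hot plate test; a higher number here means that more compound is needed for the effect, a lower number that less compound is needed: 2.8 mg/kg
Compound 2, `CON1CCC(Sc2c[nH]c3ccc(Cl)cc23)CC1`, in this assay: 2.3 mg/kg

Two compounds carry a number in this assay. Compound 2 stands at the low end of the two, but compound 1 sits within the usual scatter of it, so the two cannot be told apart on these numbers. For the measured compounds named here, compound 1 and compound 2 differ in two places at once, so their pair gives no clean step to read.

Compound 3, `CON1CCC(Sc2c[nH]c3ccc(Br)cc23)CC1`, is the next compound to be measured. It differs from compound 2 in a single place: bromo in place of chloro on an aromatic carbon. Going by the values given here, no measured pair in this set isolates that exchange, so there is no step to lean on. Compound 1, which also carries the bromo, gives a number within the scatter of compound 2, and nothing in the set points to a shift from this exchange beyond the scatter. The step from compound 2 to compound 3 is therefore expected to be a 1.1-fold higher number from compound 2 to compound 3 (0.04 log units; within the scatter). Compound 3 is expected to give 2.5 mg/kg in this assay, with a range from 1.2 mg/kg to 5 mg/kg.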

Compound 3, dose for half-maximal effect: 3.2 mg/kg
For compound 3 the middle estimate is 1.3-fold (0.11 log units) below the measured one; low and high end bracket the measured number.
By their numbers in this assay, from the lowest: compounds 2, 1 and 3 (each within the scatter of the next).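

The exchange of chloro for bromo on an aromatic carbon can now be read on its own: in this assay it comes to a 1.4-fold higher number from compound 2 to compound 3 (0.14 log units; within the scatter) and so leaves the two halogens indistinguishable at this position of the shared core. For the compounds shown here, compound 3 also gives the first clean reading at the amine nitrogen in a ring, where methoxy in place of acetyl, with the bromo held fixed, comes to a 1.1-fold higher number from compound 1 to compound 3 (0.06 log units; within the scatter) and so does not separate these two groups either. Nothing measured here bears on why the numbers of the three compounds stay so close.

What the compounds shown leave open is whether a change of another kind would move the number beyond the scatter, such as an amine or a carboxylic acid on that aromatic carbon, or a longer chain on the ring nitrogen. On these data alone, it also remains open whether chloro and bromo would match as closely with acetyl on that nitrogen as they do with methoxy.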